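The compounds below may be only part of what the source reports. "The series", "measured", "known", "first", "only" and "open" are said of these compounds alone.

Measured compounds: compound 1 `C#Cc1cn([C@@H]2O[C@H](CO)[C@@H](O)[C@H]2O)c2ncnc(N(C)C)c12`, 410 nM; compound 2 `O=c1[nH]cnc2c1c(-c1ccco1)cn2[C@@H]1O[C@H](CO)[C@@H](O)[C@H]1O`, > 100000 nM; compound 3 `C#Cc1cn([C@@H]2O[C@H](CO)[C@@H](O)[C@H]2O)c2ncnc(NC)c12`, 86000 nM.

In an ADME assay on BJ cells (Homo sapiens), read by MTT assay, with a stated time of 72 h (a lower number here means a stronger inhibitor, a higher number a weaker inhibitor), compound 3 gives 86000 nM, the highest of the two numbers recorded; its nearest neighbour is compound 1, which gives 410 nM. Compound 2 gives > 100000 nM, which is a limit of the assay rather than a number, the limit described in the limit of > 100000 nM in this assay, at which 1 of the 3 values shown sits.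

Among the measured compounds shown here, the only step measured within this set is a 210-fold higher number from compound 1 to compound 3 (2.32 log units; beyond the scatter), a change of hydrogen in place of methyl on a nitrogen on an aromatic ring. The step from compound 3 to compound 4 `CNc1ncnc2c1c(-c1cccs1)cn2[C@@H]1O[C@H](CO)[C@@H](O)[C@H]1O` is of another kind: thiophen-2-yl in place of ethynyl on an aromatic carbon. For the measured compounds named here, no measured pair differs in this place alone, so the step from compound 1 to compound 3 does not bear on it, and compound 2, which differs from compound 4 in more than one place, offers only a limit. There is thus no shown basis for expecting a step in either direction beyond the scatter, and compound 3 already sits close to the limit.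

For compound 4 the expected step is a 1.0-fold higher number from compound 3 to compound 4 (0.02 log units; within the scatter), and the estimate for compound 4 in this assay is 90000 nM, within 15000 nM to 500000 nM.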

Compound 4, half-maximal inhibitory concentration: > 100000 nM
Compound 4: no number, only a limit (the forecaster's own chance of this, stated with the estimate: 40%); middle value at least 1.1-fold (0.04 log units) from the limit.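

In this assay compound 4 gives > 100000 nM, which is a limit of the assay and not a number. Among the compounds shown here, the exchange of ethynyl for thiophen-2-yl on this aromatic carbon is the first change at this place that the set allows to be read, and it comes out as an at least 1.1-fold higher number from compound 3 to compound 4 (0.06 log units; that floor lies within the scatter), so thiophen-2-yl brings no measurable gain over ethynyl on the core of compound 3, while any loss is left without a size. The comparison is open on its upper side, and what it shows is therefore only a floor: the limit of > 100000 nM in this assay, at which 2 of the 4 values shown sit.

As far as these compounds go, it remains open whether the same exchange would give a readable step on the core of compound 1, which gives 410 nM. Also open, from the compounds shown here alone, is how an amine, a carboxylic acid or a longer carbon chain in place of ethynyl on this aromatic carbon would read, on either core.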